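Swapping Methoxy for Chloro in a Weak Cytotoxic Series

The source may report more compounds than this note shows. Statements on the series, on what has been measured and on what is new or still open speak of the compounds shown alone.

Going by the values given here, compound 2 `COc1ccc(Nc2nc(-c3cccc(F)c3)nc3ccc(F)cc23)cc1` is the only compound here with a numeric result in a functional assay on HL-60 cells (Homo sapiens) for cytotoxicity, read by MTT assay, with a stated time of 48 h (a lower number here means a stronger inhibitor, a higher number a weaker inhibitor), where compound 2 gives 38600 nM. Compound 1 `Fc1ccc2nc(-c3ccccc3)nc(Nc3ccccc3)c2c1` reaches only a limit of the assay, > 50000 nM. Compound 3 `Fc1cccc(-c2nc(Nc3ccccc3F)c3cc(F)ccc3n2)c1` likewise reaches only a limit, > 50000 nM. Because the limit of > 50000 nM in this assay, at which 2 of the 3 values shown sit, caps two of the three results, the step of an at least 1.2-fold higher number from compound 2 to compound 3 (0.11 log units; that floor lies within the scatter) is only a floor and sits within scatter. Compound 4 `Fc1cccc(-c2nc(Nc3ccc(Cl)cc3)c3cc(F)ccc3n2)c1` differs from compound 2 in one spot: chloro in place of methoxy on an aromatic carbon. Among the compounds with values here, no measured step exchanges a group at this spot, so no direction can be read from the data, and a series hovering at the limit leaves little room to move. Compound 4 is expected to give 45000 nM (range 15000 nM to 150000 nM), a step of a 1.2-fold higher number from compound 2 to compound 4 (0.07 log units; within the scatter) expected to stay within scatter.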

Compound 4, half-maximal inhibitory concentration: 45700 nM
Estimate against measurement, compound 4: 1.0-fold (0.01 log units) below; the range from low to high includes it.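

Going by these compounds alone, this pair gives the first readable exchange at this spot, on an aromatic carbon para to a large group: this assay shows a 1.2-fold higher number from compound 2 to compound 4 (0.07 log units; within the scatter) and so methoxy and chloro cannot be told apart here, and compound 4 joins compound 2 with a numeric result. The other step of an at least 1.0-fold lower number from compound 3 to compound 4 (0.03 log units; that floor lies within the scatter) is only a floor and cannot be read, because one of its two values is a limit: the limit of > 50000 nM in this assay, at which 2 of the 4 values shown sit.

Going by these compounds, whether an amine or a carboxylic acid at this spot would give a step beyond the scatter stays open. So does whether any change here could bring the series to much lower numbers.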